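This account rests on a few compounds, and the source may have more. Where it says the series, first, only, none or still open, it means among the compounds named here.

Measured compounds:
compound 1 `Cn1c(=O)c(C(=O)NCCCCCCN)c(O)c2ccccc21`: 3.1%
compound 2 `NCCCCCCNC(=O)c1c(O)c2ccccc2n(-c2ccccc2)c1=O`: 11.6%
compound 3 `Cn1c(=O)c(C(=O)NCCCCCCNC(=O)CCCCC2CCSS2)c(O)c2ccccc21`: 9.1%

All three were measured in a functional assay, with a stated time of 20 min, tested at 0.1 mM; a higher number here means a stronger effect of the compound at the concentration tested, a lower number a weaker effect. Within the data shown here, compound 3 has the second highest of the three numbers, but its gaps to compound 2 and to compound 1 both lie within the usual scatter, so no compound can be called stronger than another. Compound 4 `O=C(CCCCC1CCSS1)NCCCCCCNC(=O)c1c(O)c2ccccc2n(-c2ccccc2)c1=O` differs from compound 3 in one place: phenyl in place of methyl on an aromatic nitrogen. The same change on the shared core has been seen once before, in the step of a number 8.5 percentage points higher from compound 1 to compound 2 (within the scatter), which stayed within the scatter. A step of similar size, upward, is therefore expected from compound 3 to compound 4 in this assay, that is a number 7.9 percentage points higher from compound 3 to compound 4 (within the scatter). Compound 4 is estimated at 17%, with a range from 5% to 30%.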

Compound 4, a percentage reported as activity, at one concentration (the size of the read-out at that concentration, not a potency): 6.2%
Compound 4: middle estimate off by 10.8 percentage points, on the high side; the measured number falls inside the stated range.
By their numbers in this assay, from the lowest: compounds 1, 4, 3 and 2 (each within the scatter of the next).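

On the core carrying the group of 11 heavy atoms, phenyl in place of methyl on the aromatic nitrogen gives in this assay a number 2.9 percentage points lower from compound 3 to compound 4 (within the scatter), so this change now has two readings, and they do not differ by more than the scatter: the same change on two cores in this assay, a number 8.5 percentage points higher (within the scatter) from compound 1 to compound 2 and a number 2.9 percentage points lower (within the scatter) from compound 3 to compound 4, 11.4 percentage points apart, within the scatter of two such steps. The group of 11 heavy atoms on the amine nitrogen, now read on the phenyl core, gives a number 5.4 percentage points lower from compound 2 to compound 4 (within the scatter), and its two readings also stay within the scatter: the same change on two cores in this assay, a number 6 percentage points higher (within the scatter) from compound 1 to compound 3 and a number 5.4 percentage points lower (within the scatter) from compound 2 to compound 4, 11.4 percentage points apart, within the scatter of two such steps. Neither change has yet moved the number measurably at either core.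

Going by these compounds, whether an ethyl or a benzyl on the aromatic nitrogen, or a longer chain linking the two amides, would go beyond the scatter remains open. So does how these compounds behave at any other concentration.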